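The compounds below may be only part of what the source reports. "The series", "measured", "known", "first", "only" and "open" are said of these compounds alone.

Measured so far, in a functional assay on CCRF-CEM cells for agonist activity at C-X-C chemokine receptor type 4 (Homo sapiens), read by calcium flux, with a stated time of 25 min; on this read-out lower numbers stand for an effect already at smaller amounts and higher numbers for an effect only at larger amounts of compound:

Compound 1 `CN(C[C@@H]1Cc2c(cccc2N2CCNCC2)CN1)[C@H]1CCCc2cccnc21` — in this assay compound 1 gives > 30000 nM, a limit of the assay and not a number.
Compound 2 `CN(C[C@H]1Cc2c(cccc2N2CCNC(C)(C)C2)CN1)[C@H]1CCCc2cccnc21` — in this assay compound 2 gives > 30000 nM, again only a limit.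
Compound 3 `C[C@@H]1CN(c2cccc3c2C[C@H](CN(C)[C@H]2CCCc4cccnc42)NC3)C[C@H](C)N1C` — in this assay compound 3 gives > 30000 nM, also a limit.

Going by the values given here, compound 3 therefore stands where every value shown stands: all three values sit at the same limit, (the limit of > 30000 nM in this assay, at which 3 of the 3 values shown sit), and no compound can be put above or below another on these numbers.

The next compound is compound 4 `CN(C[C@H]1Cc2c(cccc2N2CCNCC2)CN1)[C@H]1CCCc2cccnc21`. It differs from compound 3 in one place: piperazin-1-yl in place of 3,4,5-trimethylpiperazin-1-yl on an aromatic carbon. Among the compounds with values here, the only measured step that touches this part of the core is a step that the two limits leave unreadable from compound 2 to compound 3, and both limits leave its size unreadable. Within the data shown here, no measured step bears on the change to piperazin-1-yl itself; compound 1 also carries piperazin-1-yl and sits at the limit.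

With nothing but limits to go on, the step of a number no higher from compound 3 to compound 4 (the limit leaves the size open) is expected to stay unreadable, and compound 4 is estimated at 30000 nM (range 10000 nM to 100000 nM), most likely reported as a limit once more.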

Compound 4, half-maximal effective concentration: > 30000 nM
Compound 4: only a limit was reported; the forecaster's own chance of this, stated with the estimate: 85%; the middle value sits exactly at the limit.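

Compound 4 gives > 30000 nM, a limit and not a number, so the steps to it from compound 1, compound 2 and compound 3 cannot be read: the limit of > 30000 nM in this assay, at which 4 of the 4 values shown sit. Left open is whether piperazin-1-yl, 3,3-dimethylpiperazin-1-yl, 3,4,5-trimethylpiperazin-1-yl or the drawn configuration makes any difference to the read-out: the fact that compounds 1 and 4 differ only in the configuration as drawn.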